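A Hydroxyl in Place of Fluorine on the Aryl Ring

The source may hold more compounds than are shown below. What is called first, only, known or untested is meant among the compounds shown, and "the series" means these compounds.

Three measured compounds share one core and differ only in the ring sitting on a carbon with a double bond to nitrogen. In a functional assay on A549 cells (Homo sapiens) for cytotoxicity, read by MTT assay, with a stated time of 72 h (on this read-out lower numbers stand for stronger inhibition and higher numbers for weaker inhibition), compound 1 `CN(C)CCn1cnnc1-c1cc(Oc2ccc(NC(=O)N/N=C/c3c[nH]c4ccccc34)cc2F)ccn1` gives 820 nM. Compound 2 `CN(C)CCn1cnnc1-c1cc(Oc2ccc(NC(=O)N/N=C/c3ccc(F)cc3)cc2F)ccn1` carries a 4-fluorophenyl there, and in this assay compound 2 gives 1790 nM, the higher of the two plain numbers, with compound 1 as its nearest neighbour. Compound 3 `COc1cc(/C=N/NC(=O)Nc2ccc(Oc3ccnc(-c4nncn4CCN(C)C)c3)c(F)c2)ccc1O` carries a 4-hydroxy-3-methoxyphenyl, and in this assay compound 3 gives > 100000 nM, which is a limit of the assay and not a number. That value sits at the limit of > 100000 nM in this assay, at which 1 of the 3 values shown sits.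

Among the steps, a 2.2-fold higher number from compound 1 to compound 2 (0.34 log units; beyond the scatter) is modest, whereas an at least 120-fold higher number from compound 1 to compound 3 (2.08 log units; beyond the scatter) and an at least 55-fold higher number from compound 2 to compound 3 (1.74 log units; beyond the scatter) are both large.

Compound 4 `CN(C)CCn1cnnc1-c1cc(Oc2ccc(NC(=O)N/N=C/c3cccc(O)c3)cc2F)ccn1` has not yet been measured. (3-hydroxyphenyl in place of 4-fluorophenyl on a carbon with a double bond to nitrogen). For the measured compounds named here, the change most like it is the one from compound 2 to compound 3, which also brings a hydroxyl onto that ring, although together with a methoxy, and gave an at least 55-fold higher number from compound 2 to compound 3 (1.74 log units; beyond the scatter). A weakening is therefore expected, but a smaller one, as only the hydroxyl enters here. Compound 4 is expected to give about 9000 nM in this assay, within a range from 2500 nM to 60000 nM. That expectation amounts to a 5.0-fold higher number from compound 2 to compound 4 (0.70 log units; beyond the scatter).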

Compound 4, half-maximal inhibitory concentration: > 100000 nM
Compound 4: no number, only a limit; the forecaster's own chance of this, stated with the estimate: 20%; middle value at least 11-fold (1.04 log units) away from the limit.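

Compound 3 carried a methoxy as well as a hydroxyl, so it could not show whether a hydroxyl without a methoxy would also cost this much, but compound 4 shows that it can in this assay, with an at least 55-fold higher number from compound 2 to compound 4 (1.74 log units; beyond the scatter) and an at least 120-fold higher number from compound 1 to compound 4 (2.08 log units; beyond the scatter). Compound 4 gives a limit of the assay and not a number, and the step from compound 3 to compound 4 cannot be read, because both compounds rest on the same limit: the limit of > 100000 nM in this assay, at which 2 of the 4 values shown sit. The loss in compound 4 comes from a single swap on the ring, but that swap both exchanges fluorine for hydroxyl and places the group differently, as the names 4-fluorophenyl and 3-hydroxyphenyl show, so the two changes cannot be told apart.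

The compounds shown leave open whether the hydroxyl itself or its place on the ring matters, which a 4-hydroxyphenyl or a 3-fluorophenyl at this carbon would help to settle. They also leave open how an amine or a carboxylic acid on this ring would behave, and how far compound 3 and compound 4 differ from each other.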